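From fluoro to methyl: an untested change

The source may report more compounds than this note shows. Statements on the series, on what has been measured and on what is new or still open speak of the compounds shown alone.

Compound 1 `CCNC(=O)c1ccc(-c2cc3nnn(C4CCN(c5ncc(CC)cn5)CC4)c3cn2)c(F)c1` gives 15 nM in a functional assay on HEK293 cells for agonist activity at Glucose-dependent insulinotropic receptor (Homo sapiens), read by HTRF and cAMP accumulation, with a stated time of 30 min (a lower number here means that less compound is needed, a higher number that more compound is needed for the effect), the higher of the two measured numbers. Its near neighbour, compound 2 `CCNC(=O)c1ccc(-c2cc3nnn(C4CCN(c5ncc(CC)cn5)CC4)c3cn2)c(F)c1F`, gives 10 nM in this assay; the step of a 1.5-fold lower number from compound 1 to compound 2 (0.18 log units; within the scatter) adds a second fluoro elsewhere on the same ring and stays within the scatter. Compound 3 `CCNC(=O)c1ccc(-c2cc3nnn(C4CCN(c5ncc(CC)cn5)CC4)c3cn2)c(C)c1` carries the change (methyl in place of fluoro on an aromatic carbon), ortho to a large group and meta to the ethylcarbamoyl group. Within the data shown here, no measured step touches this position, so the only guide is that one small change on this ring left the number essentially unmoved. Compound 3 is therefore expected to stay close to that level, with an estimated step of a 1.3-fold higher number from compound 1 to compound 3 (0.12 log units; within the scatter) and an estimated value of 20 nM, ranging from 7 nM to 60 nM.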

Compound 3, half-maximal effective concentration: 19 nM
Compound 3: the middle estimate sits 1.1-fold (0.02 log units) above what was measured, and the stated range covers the measured number.
By their numbers in this assay, from the lowest: compounds 2, 1 and 3 (each within the scatter of the next).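

In this assay, among these compounds, the step of a 1.3-fold higher number from compound 1 to compound 3 (0.10 log units; within the scatter) is the first direct reading at this position, ortho to a large group, and it leaves methyl and fluoro indistinguishable here. Compound 3 thus shows that swapping the fluoro itself, and not only adding a fluoro elsewhere on the ring as in compound 2, stays within the scatter. Nothing at hand explains this result.

As far as these compounds go, whether a methoxy group or an amine at this position would also stay within the scatter remains open.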